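A Methoxyphenyl Variant in a Rat Inhibition Series

The source may hold more compounds than are shown below. What is called first, only, known or untested is meant among the compounds shown, and "the series" means these compounds.

Compound 1 `C[C@H]1CCC(=NNc2ccccc2)c2ncc(C(=O)O)c(=O)n21`: 1 umol/kg; > 100 umol/kg (2 entries)
Compound 2 `CC1CCn2c(ncc(C(=O)O)c2=O)/C1=N/Nc1ccccc1`: > 320 umol/kg
Compound 3 `CC1CC/C(=N\Nc2ccccc2Br)c2ncc(C(=O)O)c(=O)n21`: > 320 umol/kg

In a functional assay on the whole organism for inhibition, with Rattus norvegicus as the target (a higher number here means that more compound is needed for the effect, a lower number that less compound is needed), compound 1 gives 1 umol/kg; > 100 umol/kg (2 entries), entries that disagree with each other (the several entries of compound 1 in this assay, 1 umol/kg; > 100 umol/kg (2 entries)). For compound 2 the value > 320 umol/kg is a limit of the assay. For compound 3 the value > 320 umol/kg is also a limit of the assay, so compound 3 stands at the edge where two of the three values sit (the limit of > 320 umol/kg in this assay, at which 2 of the 3 values shown sit). Compound 4 `COc1ccc(N/N=C2\CCC(C)n3c2ncc(C(=O)O)c3=O)cc1` is not yet measured; it differs from compound 3 by 4-methoxyphenyl in place of 2-bromophenyl on an amine nitrogen. Within the data shown here, no step between measured compounds exists here, so no direction beyond the scatter can be foreseen. Compound 4 is expected to give 250 umol/kg, between 30 umol/kg and 1000 umol/kg, most likely again a limit. The expected step of an at least 1.2-fold lower number from compound 3 to compound 4 (0.10 log units; that floor lies within the scatter) is therefore small.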

Compound 4, dose for 50% inhibition: 7.6 umol/kg
Compound 4: the middle estimate sits 33-fold (1.52 log units) above what was measured, and the stated range ends above it.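

In this assay, the group on the amine nitrogen clearly matters: 4-methoxyphenyl in place of 2-bromophenyl gives an at least 42-fold lower number from compound 3 to compound 4 (1.62 log units; beyond the scatter). As far as these compounds go, compound 3 gives > 320 umol/kg, which is a limit of the assay, so the full size of this step remains unknown. Compound 4 is also the first compound here with a single exact value, since the entries for compound 1 disagree: the several entries of compound 1 in this assay, 1 umol/kg; > 100 umol/kg (2 entries)

From the compounds shown here alone, it stays open whether the methoxy group or its place on the ring carries the step, a question that 2-methoxyphenyl or 4-bromophenyl on the same nitrogen could answer. Going by these compounds, how a 4-ethoxyphenyl group would compare is also open.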